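This account rests on a few compounds, and the source may have more. Where it says the series, first, only, none or still open, it means among the compounds named here.

Measured so far:
compound 1, `Cc1cc(/C=C/C#N)cc(C)c1Oc1cc(Nc2ccc(C#N)cc2)c(N)cc1C(N)=O`, 2.09 ug/mL in a physicochemical assay for solubility, read by HPLC, with a stated time of 4 h, at pH 2; a higher number here means a more soluble compound, a lower number a less soluble compound
compound 2, `Cc1cc(/C=C/C#N)cc(C)c1Oc1cc(Nc2ccc(C#N)cc2)c(N)cc1C(=O)NCCC(F)F`, 57.6 ug/mL

Among these two numbers compound 2 stands highest, and its only neighbour is compound 1, reached by a 28-fold higher number from compound 1 to compound 2 (1.44 log units; beyond the scatter). Compound 3, `Cc1cc(/C=C/C#N)cc(C)c1Oc1cc(Nc2ccc(C#N)cc2)c(N)cc1C(=O)N1CC1`, has not yet been measured in this assay. It differs from compound 2 in one place: aziridin-1-yl in place of (3,3-difluoropropyl)amino on a carbonyl carbon. The group that enters has no hydrogen-bond donor, where the group that leaves had one. Among the measured compounds shown here, only one measured step bears on this spot, the change from a hydrogen to the 3,3-difluoropropyl chain on the amide nitrogen, which gave a 28-fold higher number from compound 1 to compound 2 (1.44 log units; beyond the scatter), a large gain. Removing that chain again and closing the nitrogen into a three-membered ring gives a compound lying between the two measured ones in size, so a drop from compound 2 is expected, though smaller than the full step back to compound 1. The estimated step is a 3.8-fold lower number from compound 2 to compound 3 (0.58 log units; beyond the scatter). For compound 3 the expected value in this assay is 15 ug/mL, within a range from 4 ug/mL to 60 ug/mL.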

Compound 3, solubility: 94.2 ug/mL
Compound 3: middle estimate off by 6.3-fold (0.80 log units), on the low side, and the stated range ends below it.
By their numbers in this assay, from the lowest: compound 1; then compounds 2 and 3 (each within the scatter of the next).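

In this assay, a large step at this carbonyl carbon does not depend on the 3,3-difluoropropyl chain: replacing the amino group with aziridin-1-yl gives a 45-fold higher number from compound 1 to compound 3 (1.65 log units; beyond the scatter), a step of the same large kind as the one seen with the chain. Comparing the two groups directly gives a 1.6-fold higher number from compound 2 to compound 3 (0.21 log units; within the scatter), so they cannot be told apart here, even though the aziridin-1-yl group has no hydrogen-bond donor and the chain it replaces has one. No measurement shown explains these numbers.

As far as these compounds go, it remains open whether the three-membered ring matters or whether any fully substituted amide nitrogen would read the same way. A dimethylamino group, or a larger ring such as azetidine or pyrrolidine on the same carbonyl carbon, would help separate those two possibilities.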